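The source may report more compounds than this note shows. Statements on the series, on what has been measured and on what is new or still open speak of the compounds shown alone.

In a functional assay on A549 cells (Homo sapiens) for cytotoxicity (on this read-out lower numbers stand for an effect already at smaller amounts and higher numbers for an effect only at larger amounts of compound), compound 1 (`COC1=C(C)C(=O)/C(=C(O)/C=C/c2ccc(O)cc2)C(=O)C1(C)C`) gives 3.1 ug/mL, compound 2 (`COC1=C(C)C(=O)/C(=C(O)/C=C/c2c(C)cccc2C)C(=O)C1(C)C`) gives 8.3 ug/mL and compound 3 (`COC1=C(C)C(=O)/C(=C(O)/C=C/c2cc(C)cc(C)c2)C(=O)C1(C)C`) gives 4.3 ug/mL. Compound 2 stands at the high end of these numbers: a 2.7-fold higher number from compound 1 to compound 2 (0.43 log units; beyond the scatter) goes beyond the scatter, while a 1.9-fold lower number from compound 2 to compound 3 (0.29 log units; within the scatter) and a 1.4-fold higher number from compound 1 to compound 3 (0.14 log units; within the scatter) do not. Compound 4 (`COC1=C(C)C(=O)/C(=C(O)/C=C/c2c(C)cc(C)cc2C)C(=O)C1(C)C`) differs from compound 2 by methyl in place of hydrogen on an aromatic carbon, a methyl in place of hydrogen on an aromatic carbon, para to a large group. Among the measured compounds shown here, no measured pair shows this change alone. The nearest guides are the modest steps between the aryl variants, the largest being a 2.7-fold higher number from compound 1 to compound 2 (0.43 log units; beyond the scatter). In this assay, the expected result is a 1.1-fold lower number from compound 2 to compound 4 (0.04 log units; within the scatter), with no change beyond the scatter. Compound 4 is estimated at 7.5 ug/mL, within an expected range of 3.5 ug/mL to 16 ug/mL.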

Compound 4, concentration for half-maximal effect: 8 ug/mL
Beside the measured number, compound 4's estimate is 1.1-fold (0.03 log units) below it; the range from low to high includes it.
By their numbers in this assay, from the lowest: compounds 1, 3, 4 and 2 (each within the scatter of the next, the first and the last beyond it).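

In this assay, methyl in place of hydrogen on the aromatic carbon para to a large group and meta to two methyl groups gives a 1.0-fold lower number from compound 2 to compound 4 (0.02 log units; within the scatter). Among the compounds shown here, this is the first reading of this change alone, and it shows that, on this ring, adding a methyl at this position leaves the number within the scatter. Nothing at hand offers a reason for this result. The compounds shown leave open whether an amine, a carboxylic acid or a longer chain at this position would also leave the number unchanged. They also leave open how this methyl would read on a ring without the two methyl groups.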